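Replacing the 4-chlorophenyl group of compound 2

The compounds below may be only part of what the source reports. "The series", "measured", "known", "first", "only" and "open" are said of these compounds alone.

In a functional assay on A549 cells (Homo sapiens) for antiproliferative activity, read by MTT assay, with a stated time of 48 h (on this read-out higher numbers stand for weaker inhibition and lower numbers for stronger inhibition), compound 1 `COc1ccc(/C=C/c2cc(OC)cc(OC)c2/C=C/C(=O)c2cccc(Cl)c2)cc1` gives 5.6 ug/mL and compound 2 `COc1ccc(/C=C/c2cc(OC)cc(OC)c2/C=C/C(=O)c2ccc(Cl)cc2)cc1` gives 6.4 ug/mL. For the measured compounds named here, these are the only two numbers so far, and they lie within the usual scatter of each other, so compound 2 stands level with compound 1.

Going by the values given here, compound 3 `COc1ccc(/C=C/c2cc(OC)cc(OC)c2/C=C/C(=O)c2ccc(C)cc2C)cc1` keeps the core of compound 2 and changes only one group: 2,4-dimethylphenyl in place of 4-chlorophenyl on a carbonyl carbon. In words, this is 2,4-dimethylphenyl in place of 4-chlorophenyl on a carbonyl carbon. Just one measured step bears on this change, the exchange of 3-chlorophenyl for 4-chlorophenyl at the same carbonyl carbon. That step, a 1.1-fold higher number from compound 1 to compound 2 (0.06 log units; within the scatter), stays within the scatter. Among the compounds with values here, it compares only two chlorophenyl groups, however, and no measured compound carries methyl groups, so the data give no direction for the new change and only weak guidance on its size. The expectation is therefore no shift beyond the scatter, and the expected step is a 1.0-fold higher number from compound 2 to compound 3 (0.01 log units; within the scatter). The estimated value for compound 3 is 6.5 ug/mL, with an expected range of 3 ug/mL to 14 ug/mL.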

Compound 3, half-maximal inhibitory concentration: 0.3 ug/mL
Estimate against measurement, compound 3: 22-fold (1.34 log units) above; the whole stated range lies above it.
By their numbers in this assay, from the lowest: compound 3; then compounds 1 and 2 (each within the scatter of the next).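

In this assay, for the compounds shown here, the group on the carbonyl carbon proves able to move the number a long way: a 21-fold lower number from compound 2 to compound 3 (1.33 log units; beyond the scatter), and likewise a 19-fold lower number from compound 1 to compound 3 (1.27 log units; beyond the scatter), whereas the only earlier step, a 1.1-fold higher number from compound 1 to compound 2 (0.06 log units; within the scatter), stayed within the scatter and showed no such sensitivity. This stronger inhibition comes from a change that the computed description barely separates, since 4-chlorophenyl and 2,4-dimethylphenyl each hold one six-membered aromatic ring of carbon only, with no hydrogen-bond donors or acceptors and no net charge. No measurement here accounts for the large step.

From the compounds shown here alone, the change removes a chlorine and adds two methyl groups in a single move, so it remains open whether one methyl group alone would give the same drop, whether both are needed, and whether losing the chlorine plays any part. Going by these compounds, how an amine or a carboxylic acid on this phenyl ring would behave also remains open, as does whether a larger group such as ethyl would take the number lower still or lose the gain.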